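The source may report more compounds than this note shows. Statements on the series, on what has been measured and on what is new or still open speak of the compounds shown alone.

Working notes on the series. Compound 1 `Cc1cc(S(=O)(=O)/N=C(\N)n2nccc2-c2ccccc2)c(SCc2ccc(Cl)cc2)cc1Cl` is the starting point; in a functional assay on HeLa cells (Homo sapiens) for cytotoxicity, read by MTT assay, with a stated time of 72 h (a higher number here means a weaker inhibitor, a lower number a stronger inhibitor), compound 1 gives 3000 nM. Compound 2 `Cc1cc(S(=O)(=O)/N=C(\N)n2nccc2-c2ccccc2)c(SCc2cccc3ccccc23)cc1Cl` gives 3000 nM, and compound 3 `Cc1cc(S(=O)(=O)/N=C(\N)n2nccc2-c2ccccc2)c(SCc2cccc(C(F)(F)F)c2)cc1Cl` gives 19000 nM. Compound 1 stands level with compound 2, the two together giving the lowest numbers of the three measured, with no change at the digits printed from compound 1 to compound 2 (within the scatter). Against compound 3 the picture differs: a 6.3-fold higher number from compound 1 to compound 3 (0.80 log units; beyond the scatter) and a 6.3-fold higher number from compound 2 to compound 3 (0.80 log units; beyond the scatter).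

Compound 4 `Cc1cc(S(=O)(=O)/N=C(\N)n2nccc2-c2ccccc2)c(SCc2ccccc2C(F)(F)F)cc1Cl` is not yet measured. Its difference from compound 1 is 2-(trifluoromethyl)phenyl in place of 4-chlorophenyl on a saturated chain carbon bound to a sulfur. Among the compounds with values here, the step that bears most directly on this is the one from compound 1 to compound 3, where a trifluoromethylphenyl group also replaced the 4-chlorophenyl on the saturated chain carbon bound to a sulfur and gave a 6.3-fold higher number from compound 1 to compound 3 (0.80 log units; beyond the scatter). Nothing measured separates the two trifluoromethylphenyl groups from each other, so the direction is taken from that step and its size is tempered. Compound 4 is expected to give 10000 nM, with a range of 3000 nM to 30000 nM. That estimate means a 3.3-fold higher number from compound 1 to compound 4 (0.52 log units; beyond the scatter).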

Compound 4, half-maximal inhibitory concentration: 20000 nM
The estimate for compound 4 lay 2.0-fold (0.30 log units) below the measured number; the range from low to high includes it.
By their numbers in this assay, from the lowest: compounds 1 and 2 (each within the scatter of the next); then compounds 3 and 4 (each within the scatter of the next).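

In this assay, the 2-(trifluoromethyl)phenyl group gives a 6.7-fold higher number from compound 1 to compound 4 (0.82 log units; beyond the scatter) and a 6.7-fold higher number from compound 2 to compound 4 (0.82 log units; beyond the scatter) on a saturated chain carbon bound to a sulfur, so the higher number seen with compound 3 is not confined to the 3-(trifluoromethyl)phenyl group. The exchange of the two trifluoromethylphenyl groups gives a 1.1-fold higher number from compound 3 to compound 4 (0.02 log units; within the scatter) and so does not separate them in this assay, which leaves both groups together on the higher side of the 4-chlorophenyl and naphthalen-1-yl groups among these four compounds. No measurement at hand gives a reason for this split.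

The compounds shown leave open how a plain phenyl group would compare at this place, which would show whether the chlorine or the trifluoromethyl group accounts for the gap. They also leave open whether a carboxylic acid or an amine on the phenyl ring would be tolerated.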